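Methoxypiperidine isomer swap on the shared core

A few compounds are considered here, and "the series" means these few. Any claim that something is new, unique, unknown or untested is made for them only; others in the source may bear on it.

Compound 1 `O=S(=O)(c1ccc(Cl)cc1)N1CC(c2nc(-c3cccc(Cl)c3)no2)C1` gives 170 nM in an assay on HEK293 cells for negative allosteric modulation of metabotropic glutamate receptor 5 (Homo sapiens), read by FLIPR; a lower number here means a stronger inhibitor, a higher number a weaker inhibitor. Compound 2 `COC1CCN(C(=O)N2CC(c3nc(-c4cccc(Cl)c4)no3)C2)CC1` is a different case: in this assay compound 2 returns > 10000 nM, which is a limit of the measurement and not a number. Compound 2 thus stands at the limit of > 10000 nM in this assay, at which 1 of the 2 values shown sits, and the two values shown place it well apart from compound 1.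

Compound 3 `COC1CCCN(C(=O)N2CC(c3nc(-c4cccc(Cl)c4)no3)C2)C1` differs from compound 2 in one place: 3-methoxypiperidin-1-yl in place of 4-methoxypiperidin-1-yl on a carbonyl carbon. The attachment through the carbonyl carbon, with the amide-type nitrogen in a ring as its other neighbour, is kept; only the position of the methoxy group on the piperidine ring moves.

Within the data shown here, no measured pair shows a step of this kind. The step from compound 2 to compound 3 is expected to be a step that the limit leaves unreadable from compound 2 to compound 3, with no direction beyond the scatter, since compound 2 already sits at the limit of > 10000 nM in this assay, at which 1 of the 2 values shown sits. Compound 3 is expected to give 12000 nM, within 3000 nM to 40000 nM, and most likely again only a limit.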

Compound 3, half-maximal inhibitory concentration: 1830 nM
Beside the measured number, compound 3's estimate is 6.6-fold (0.82 log units) above it, outside the stated range (below it).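

On the carbonyl carbon whose other neighbour is an amide-type nitrogen in a ring, moving the methoxy group around the piperidine ring is enough to change the reading in this assay: 3-methoxypiperidin-1-yl in place of 4-methoxypiperidin-1-yl gives an at least 5.4-fold lower number from compound 2 to compound 3 (0.73 log units; beyond the scatter). The two groups count the same atoms, the same ring and the same hydrogen-bond acceptor, so the series now holds a pair in which only the joining differs and the number still moves beyond the scatter. The true size of the step stays unknown because compound 2 gives only a limit of the assay: the limit of > 10000 nM in this assay, at which 1 of the 3 values shown sits.

From the compounds shown here alone, whether 3-hydroxypiperidin-1-yl or morpholin-4-yl would hold or extend this gain remains open. Going by these compounds, it is also open how 2-methoxypiperidin-1-yl on the same carbonyl carbon would read.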